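The source may hold more compounds than are shown below. What is called first, only, known or untested is meant among the compounds shown, and "the series" means these compounds.

Measured compounds:
compound 1, `C#CCSc1nc(NCCC#N)c2ccncc2n1`, > 80000 nM
compound 2, `C#CCSc1nc(Nc2ccc(OC)cc2)c2ccncc2n1`, 15100 nM

In a functional assay on PC-3 cells (Homo sapiens) for inhibition, read by MTT assay, with a stated time of 72 h (a higher number here means a weaker inhibitor, a lower number a stronger inhibitor), compound 1 gives > 80000 nM, which is a limit of the assay and not a number. Within the data shown here, compound 2 gives 15100 nM in this assay, the only number so far; the other value is the limit of > 80000 nM in this assay, at which 1 of the 2 values shown sits. Compound 3, `C#CCSc1nc(Nc2ccc(O)cc2)c2ccncc2n1`, differs from compound 2 by hydrogen in place of methyl on an oxygen on an aromatic ring. Among the measured compounds shown here, no measured pair shows this change, so the expected step of a 1.0-fold lower number from compound 2 to compound 3 (0.00 log units; within the scatter) is small, not clearly beyond the scatter in either direction. Compound 3 is estimated at 15000 nM, between 5000 nM and 45000 nM.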

Compound 3, half-maximal inhibitory concentration: > 80000 nM
Compound 3 ended at the assay's limit; the forecaster's own chance of this, stated with the estimate: 10%; middle value at least 5.3-fold (0.72 log units) from the limit.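

In this assay, among these compounds, the methoxy to hydroxy change gives the first readable step: an at least 5.2-fold higher number from compound 2 to compound 3 (0.72 log units; beyond the scatter). On this oxygen on an aromatic ring, hydrogen therefore does not stand in for methyl without loss. Compound 3 stands at a limit of the assay, not a number, so the step is a bound and the step from compound 1 to compound 3 cannot be read: the limit of > 80000 nM in this assay, at which 2 of the 3 values shown sit.

Still open, going by these compounds, is whether the methyl itself matters or any carbon group on that oxygen would serve. An ethyl on the oxygen, or an amine in its place, would test this against compound 2.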